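Thioether series: trimming the benzylic carbon of compound 1

A few compounds are considered here, and "the series" means these few. Any claim that something is new, unique, unknown or untested is made for them only; others in the source may bear on it.

Among the measured compounds shown here, compound 1 `Cn1ncc2c(=O)n(-c3ccccc3)c(SC(C)(C)c3ccccc3)nc21` gives 1900 nM in an assay on isolated protein for inhibition of aldehyde dehydrogenase 1A1 (Homo sapiens) (a lower number here means a stronger inhibitor, a higher number a weaker inhibitor), the highest of the three numbers measured so far. Compound 2 `Cn1ncc2c(=O)n(-c3ccccc3)c(CCc3cccc(F)c3)nc21` gives 1000 nM, within the scatter of compound 1. Compound 3 `Cn1ncc2c(=O)n(-c3ccccc3)c(/C=C/c3cccc(F)c3)nc21` gives 270 nM, a lower number than compound 1 and beyond the scatter.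

Compound 4 `C[C@H](Sc1nc2c(cnn2C)c(=O)n1-c1ccccc1)c1ccccc1` differs from compound 1 in one place: 1-phenylethyl in place of 1-methyl-1-phenylethyl on a sulfur. For the measured compounds named here, no measured pair covers this change, so the expectation rests on the small size of the edit, one carbon fewer on the same sulfur-linked group; the step from compound 1 to compound 4 is expected to be small, with no clear direction beyond the scatter, as a 1.3-fold lower number from compound 1 to compound 4 (0.10 log units; within the scatter) states. Compound 4 is thus estimated at 1500 nM, with a range of 500 nM to 4500 nM.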

Compound 4, half-maximal inhibitory concentration: 1410 nM
Compound 4: the middle estimate sits 1.1-fold (0.03 log units) above what was measured; low and high end bracket the measured number.
By their numbers in this assay, from the lowest: compound 3; then compounds 2, 4 and 1 (each within the scatter of the next).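

Among the compounds shown here, on the sulfur, 1-phenylethyl in place of 1-methyl-1-phenylethyl gives a 1.3-fold lower number from compound 1 to compound 4 (0.13 log units; within the scatter) in this assay, the only one-place step so far. A single methyl on the carbon attached to the sulfur, with a defined stereocentre, therefore holds the number within the scatter of the dimethyl-substituted group. Nothing measured here bears on a cause for this step.

As far as these compounds go, the opposite configuration at the stereocentre remains open. So does the effect of a plain benzyl group or a longer chain on the sulfur.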